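The source may report more compounds than this note shows. Statements on the series, on what has been measured and on what is new or still open speak of the compounds shown alone.

Measured so far in a functional assay on HeLa cells (Homo sapiens) for inhibition, with a stated time of 72 h; a higher number here means a weaker inhibitor, a lower number a stronger inhibitor:
- compound 1 `NC1CCC(Nc2nc(NCc3ccc(-c4ccccc4)cc3)c3ncn(C4CCCC4)c3n2)CC1`: 240 nM
- compound 2 `NC1CCC(Nc2nc(NCc3ccc(-c4ccco4)cc3)c3ncn(C4CCCC4)c3n2)CC1`: 71 nM
- compound 3 `NC1CCC(Nc2nc(NCc3ccc(-c4ccsc4)cc3)c3ncn(C4CCCC4)c3n2)CC1`: 220 nM

These three share one core and differ only in the aromatic group carried on a benzene-type ring. Compound 3 stands close to one of its neighbours and well apart from the other: a 1.1-fold lower number from compound 1 to compound 3 (0.04 log units; within the scatter), whereas a 3.1-fold higher number from compound 2 to compound 3 (0.49 log units; beyond the scatter). Compound 2 is thus the strongest inhibitor of the three.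

The next compound is compound 4 `NC1CCC(Nc2nc(NCc3ccc(-c4ccccc4O)cc3)c3ncn(C4CCCC4)c3n2)CC1`. It differs from compound 3 as follows: 2-hydroxyphenyl in place of thiophen-3-yl on an aromatic carbon. The change sits on an aromatic carbon, para to a large group, the same place where all the earlier changes were made.

Going by the values given here, no measured compound carries a 2-hydroxyphenyl group, so the evidence is indirect. Exchanging groups at this place has had a modest effect at most, as a 3.4-fold lower number from compound 1 to compound 2 (0.53 log units; beyond the scatter), while a 1.1-fold lower number from compound 1 to compound 3 (0.04 log units; within the scatter). Only the furan-2-yl of compound 2 stood apart, so a return to a six-membered aromatic ring gives no clear reason to expect a large shift in this assay. The expected result is a 1.2-fold lower number from compound 3 to compound 4 (0.09 log units; within the scatter), which means no change beyond the scatter is anticipated. For compound 4 the estimated value is 180 nM, with an expected range of 65 nM to 500 nM.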

Compound 4, half-maximal inhibitory concentration: 4180 nM
Compound 4: middle estimate off by 23-fold (1.37 log units), on the low side; the measured number lies above the stated range.
By their numbers in this assay, from the lowest: compound 2; then compounds 3 and 1 (each within the scatter of the next); then compound 4.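

In this assay, going by these compounds alone, this position had so far taken one aromatic ring in place of another with a modest step at most, yet adding a single hydroxy group to the phenyl ring of compound 1 gives a 17-fold higher number from compound 1 to compound 4 (1.24 log units; beyond the scatter) and so outweighs every ring exchange seen before. The other two comparisons agree in direction and size, with a 19-fold higher number from compound 3 to compound 4 (1.28 log units; beyond the scatter) and a 59-fold higher number from compound 2 to compound 4 (1.77 log units; beyond the scatter), which makes compound 4 the weakest inhibitor of the four, since all its steps lie beyond the scatter and the place that looked forgiving proves sensitive to this one small addition. No measurement shown here accounts for this loss of activity.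

As far as these compounds go, what remains open is whether the loss belongs to the hydroxy group itself or would also follow from any other group at the same spot on the phenyl ring, such as a methoxy group, a fluorine atom or an amine. From the compounds shown here alone, it is equally open whether a hydroxy group placed elsewhere on that ring would cost as much, so a single compound cannot yet separate the nature of the group from its location.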